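Adding a 4-methylbenzyl to the piperazine tail

This account rests on a few compounds, and the source may have more. Where it says the series, first, only, none or still open, it means among the compounds named here.

Compound 2 `CN1CCN(CC(=O)Nc2ccc(-c3nc(-c4ccccc4)c(-c4ccccc4)n3C)cc2)CC1`: 18.8%
Compound 1 `Cn1ccnc1SCC(=O)Nc1ccc(-c2nc(-c3ccccc3)c(-c3ccccc3)n2C)cc1`: 13.6%

Of the compounds shown here, two sharing one core have been measured in a functional assay on HT-29 cells (Homo sapiens) for cytotoxicity, read by MTT assay, with a stated time of 24 h, tested at 0.64 ug/mL; a lower number here means a weaker effect, a higher number a stronger effect of the compound at the concentration tested. Compound 2 gives 18.8%, the higher of the two numbers, but compound 1 with 13.6% sits within the scatter of it, so the two cannot be told apart. Within the data shown here, the only measured step, a number 5.2 percentage points higher from compound 1 to compound 2 (within the scatter), exchanged the group at the far end of the same side chain and stayed within the scatter.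

Compound 3 `Cc1ccc(CN2CCN(CC(=O)Nc3ccc(-c4nc(-c5ccccc5)c(-c5ccccc5)n4C)cc3)CC2)cc1` carries the change (4-methylphenyl in place of hydrogen on a saturated chain carbon bound to an amine nitrogen in a ring). Among the measured compounds shown here, this again alters only the end of that side chain, the region where the one known step produced no effect beyond the scatter. The expectation for compound 3 is therefore a step of about a number 2.2 percentage points higher from compound 2 to compound 3 (within the scatter), that is, no movement beyond the scatter. Compound 3 is estimated at 21%, with a range from 8% to 36%.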

Compound 3, a percentage reported as activity, at one concentration (the size of the read-out at that concentration, not a potency): 15.4%
Estimate against measurement, compound 3: 5.6 percentage points above, within the range that was stated.
By their numbers in this assay, from the lowest: compounds 1, 3 and 2 (each within the scatter of the next).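

Compound 3 shows that the tail can take a far bigger end group, 4-methylbenzyl in place of methyl, without a clear effect. In this assay, adding the 4-methylphenyl, with its 7 carbon atoms and aromatic ring, on a saturated chain carbon bound to an amine nitrogen in a ring gives a number 3.4 percentage points lower from compound 2 to compound 3 (within the scatter), so compound 2 and compound 3 cannot be told apart. No independent measurement is available to explain this outcome.

On these data alone, it remains open whether a carboxylic acid or an amine in place of the methyl on the new ring, or a longer chain linking that ring to the piperazine, would shift the number beyond the scatter. Each compound's read-out also comes from one concentration, so it leaves their potencies open.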